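The source may hold more compounds than are shown below. What is called first, only, known or untested is meant among the compounds shown, and "the series" means these compounds.

Measured compounds:
compound 1 `CNc1nc(NCc2ccc(NC(=O)c3ccc(C)cc3)cc2)c2ccccc2n1` — 2 ug/mL
compound 2 `Cc1ccc2c(NCc3ccc(NC(=O)c4ccc(F)cc4)cc3)nc(N3CCC3)nc2c1` — 1 ug/mL
compound 3 `CC(O)c1ccc2c(NCc3ccc(NC(=O)c4ccc(F)cc4)cc3)nc(N(C)C)nc2c1` — 18 ug/mL

In a physicochemical assay for solubility, at pH 7.4 (a higher number here means a more soluble compound, a lower number a less soluble compound), compound 3 stands highest of the three numbers: compound 1 gives 2 ug/mL and compound 2 gives 1 ug/mL, and both gaps to compound 3 lie beyond the scatter. Compound 4 `C=Cc1ccc2c(NCc3ccc(NC(=O)c4ccc(F)cc4)cc3)nc(N(C)C)nc2c1` has not yet been measured. It differs from compound 3 in one place: vinyl in place of 1-hydroxyethyl on an aromatic carbon. The vinyl that enters carries no hydrogen-bond donor and no hydrogen-bond acceptor, whereas the 1-hydroxyethyl that leaves carried one of each. Among the measured compounds shown here, no step between two measured compounds is known that isolates this change, so the expectation rests on the low values of the two compounds that lack any such group, compound 1 at 2 ug/mL and compound 2 at 1 ug/mL. The step from compound 3 to compound 4 is therefore expected to be a fall in this assay beyond the scatter, a 6.0-fold lower number from compound 3 to compound 4 (0.78 log units; beyond the scatter). Compound 4 is estimated to give 3 ug/mL, within a range from 1 ug/mL to 10 ug/mL.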

Compound 4, solubility: 1 ug/mL
Estimate against measurement, compound 4: 3.0-fold (0.48 log units) above, and the stated range covers the measured number.
By their numbers in this assay, from the lowest: compounds 2, 4 and 1 (each within the scatter of the next); then compound 3.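

In this assay, among the compounds shown here, vinyl in place of 1-hydroxyethyl on this aromatic carbon gives an 18-fold lower number from compound 3 to compound 4 (1.26 log units; beyond the scatter), the first step that isolates a change in a single place. With the rest of the structure held constant, the higher number of compound 3 goes with the 1-hydroxyethyl at this position and is not kept with the vinyl. Nothing measured here accounts for the size of this step.

The compounds shown leave open how an ethyl, a hydroxymethyl or an aminomethyl group would stand on this same aromatic carbon, and so whether the oxygen or the saturated chain of the 1-hydroxyethyl goes with the higher number. They also leave open whether the same exchange gives a step of similar size when other parts of the shared core differ.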